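This account rests on a few compounds, and the source may have more. Where it says the series, first, only, none or still open, it means among the compounds named here.

Compounds measured so far:

Compound 1: `CCCOC(=O)c1[nH]c(C(=O)NCC2CC2)c(C(=O)OC(C)(C)C)c1C` — 2500 nM
Compound 2: `CCCOC(=O)c1[nH]c(CO)c(C(=O)OC(C)(C)C)c1C` — 7900 nM
Compound 3: `CCCOC(=O)c1[nH]c(C(=O)OC)c(C(=O)OC(C)(C)C)c1C` — 3200 nM

In an assay on CHO cells for inhibition of metabotropic glutamate receptor 1 (Rattus norvegicus) (on this read-out higher numbers stand for weaker inhibition and lower numbers for stronger inhibition), compound 3 stands second highest of the three numbers; its nearest neighbour is compound 1, and the step of a 1.3-fold higher number from compound 1 to compound 3 (0.11 log units; within the scatter) lies within the scatter. The step of a 2.5-fold lower number from compound 2 to compound 3 (0.39 log units; beyond the scatter) is modest but beyond the scatter, and the step of a 3.2-fold higher number from compound 1 to compound 2 (0.50 log units; beyond the scatter) is likewise modest.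

Compound 4 is `CCCOC(=O)c1[nH]c(C(=O)Sc2ccccn2)c(C(=O)OC(C)(C)C)c1C`. It differs from compound 3 by (pyridin-2-yl)sulfanyl in place of methoxy on a carbonyl carbon. Among the compounds with values here, of the measured steps, only the one from compound 1 to compound 3 bears on this position, since it also exchanges the group on that carbonyl carbon, and a 1.3-fold higher number from compound 1 to compound 3 (0.11 log units; within the scatter) shows little sensitivity to such an exchange. The other two steps change the substituent on the aromatic carbon instead. The exchange in compound 4 is larger in what it adds than the methoxy it removes, so some uncertainty remains, but no step beyond the scatter is expected in this assay. Compound 4 is therefore estimated at 3200 nM, within 1100 nM to 9500 nM, an expected step of no change at the digits printed from compound 3 to compound 4 (within the scatter).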

Compound 4, half-maximal inhibitory concentration: 3200 nM
Beside the measured number, compound 4's estimate shows no gap at the digits printed; the measured number falls inside the stated range.
By their numbers in this assay, from the lowest: compounds 1, 3 and 4 (each within the scatter of the next); then compound 2.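

In this assay the carbonyl carbon takes (pyridin-2-yl)sulfanyl, with its six-membered aromatic ring, in place of the smaller methoxy, and the result is no change at the digits printed from compound 3 to compound 4 (within the scatter), so this larger group brings no step beyond the scatter. The exchange for (cyclopropylmethyl)amino gives a 1.3-fold higher number from compound 1 to compound 4 (0.11 log units; within the scatter), which places all three groups on this carbonyl carbon within the scatter of one another, while replacing the whole hydroxymethyl group with ((pyridin-2-yl)sulfanyl)carbonyl gives a 2.5-fold lower number from compound 2 to compound 4 (0.39 log units; beyond the scatter). Nothing measured here accounts for these results.

The compounds shown leave open whether a carboxylic acid, or a simple amine such as dimethylamino on this carbonyl carbon, would stay within the same scatter. They also leave open whether this result would hold if the propyl ester or the tert-butyl ester of the shared core were replaced by a carboxylic acid.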